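This account rests on a few compounds, and the source may have more. Where it says the series, first, only, none or still open, it means among the compounds named here.

In an ADME assay on Huh-7 cells (Homo sapiens) for cytotoxicity, read by XTT assay, with a stated time of 3 days, tested at 200 uM (a lower number here means a stronger effect, a higher number a weaker effect of the compound at the concentration tested), compound 1 `Fc1ccc2nc(-c3cc(-c4ccccc4)n(-c4ccccc4)n3)ccc2c1` gives 115%. Compound 2 `Fc1ccc(-c2cc(-c3ccc4cc(F)ccc4n3)nn2-c2ccccc2)cc1` gives 89.7% in this assay; it carries one change against compound 1, (fluoro in place of hydrogen on an aromatic carbon), and that change shows in a number 25.3 percentage points lower from compound 1 to compound 2 (beyond the scatter). Compound 3 `NS(=O)(=O)c1ccc(-n2nc(-c3ccccc3)cc2-c2ccc3cc(F)ccc3n2)cc1` gives 83.6% in this assay; how the core of compound 3 differs from that of compound 1 is not broken down here. Compound 4 `NS(=O)(=O)c1ccc(-n2nc(-c3ccc(F)cc3)cc2-c2ccc3cc(F)ccc3n2)cc1` stands to compound 3 as compound 2 stands to compound 1, with fluoro in place of hydrogen on an aromatic carbon, the same change at the same kind of place. On this basis the step expected from compound 3 to compound 4 is a number 13.6 percentage points lower from compound 3 to compound 4 (beyond the scatter), set beside and somewhat smaller than a number 25.3 percentage points lower from compound 1 to compound 2 (beyond the scatter). Compound 4 is therefore estimated at 70% in this assay, expected to fall between 50% and 90%.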

Compound 4, a percentage reported as activity, at one concentration (the size of the read-out at that concentration, not a potency): 43%
Estimate against measurement, compound 4: 27 percentage points above; measured number outside the range, below it.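

On the core of compound 3, fluoro in place of hydrogen on an aromatic carbon, which turns phenyl into 4-fluorophenyl, gave a number 40.6 percentage points lower from compound 3 to compound 4 (beyond the scatter) in this assay. The direction of the step carried from one core to the other, but its size did not: the same change on two cores in this assay, a number 25.3 percentage points lower (beyond the scatter) from compound 1 to compound 2 and a number 40.6 percentage points lower (beyond the scatter) from compound 3 to compound 4, 15.3 percentage points apart, beyond the scatter of two such steps

Among the compounds shown here, with only two such pairs, this does not show what sets the size of the step or how large it would be on any further core. The compounds shown leave open whether chloro, methoxy or an amine at the same place would lower the number as fluoro does. They also leave open whether either core would respond to those groups to a different degree.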